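Chloro for Isopropyl on an Oxindole-Type Cytotoxicity Series

This account rests on a few compounds, and the source may have more. Where it says the series, first, only, none or still open, it means among the compounds named here.

Measured so far:
compound 1 `CN1C(=O)/C(=C/C(=O)O)c2ccccc21`, no result reported;
compound 2 `CC(C)c1ccc2c(c1)/C(=C\C(=O)OC(C)(C)C)C(=O)N2`, 3360 nM.

In a toxicity assay on L02 cells (Homo sapiens) for cytotoxicity, read by CCK-8 assay, with a stated time of 72 h (a lower number here means a stronger inhibitor, a higher number a weaker inhibitor), compound 2 gives 3360 nM. It is the only compound with a number here; compound 1 `CN1C(=O)/C(=C/C(=O)O)c2ccccc21` gives no result reported in this assay, no single number came out of it, so compound 2 stands alone on the numbers shown.

Compound 3 `CC(C)(C)OC(=O)/C=C1/C(=O)Nc2ccc(Cl)cc21` is made from compound 2 by one change: chloro in place of isopropyl on an aromatic carbon. For the measured compounds named here, no step between two measured compounds is known, so the size of this step must be expected rather than read off. A small to moderate weakening is expected, a step not much beyond the scatter, given that compound 2 sits at 3360 nM and nothing in the data points to a larger shift. The expected step is a 1.5-fold higher number from compound 2 to compound 3 (0.17 log units; within the scatter). Compound 3 is expected to give 5000 nM, within 1500 nM to 15000 nM.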

Compound 3, half-maximal inhibitory concentration: 4720 nM
Compound 3: middle estimate off by 1.1-fold (0.03 log units), on the high side; measured number inside the range.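

In this assay, the exchange of isopropyl for chloro on this aromatic carbon, meta to a fused ring and para to a fused ring, gives a 1.4-fold higher number from compound 2 to compound 3 (0.15 log units; within the scatter) and so leaves the two compounds indistinguishable. For the compounds shown here, this is the first step that can be read at this position, and it shows that a group of 3 heavy atoms can give way to one of 1 heavy atom with no difference beyond the scatter. Nothing measured here bears on why the number holds across this change.

On these data alone, whether an amine, a methoxy group or a longer chain on this carbon would shift the number beyond the scatter remains open. As far as these compounds go, compound 1 offers no number for comparison, so the effect of changes elsewhere on the shared core also remains open.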